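Chloro in place of fluoro: compound 3 to compound 4

The source may report more compounds than this note shows. Statements on the series, on what has been measured and on what is new or still open speak of the compounds shown alone.

In a functional assay on HCT-116 cells (Homo sapiens) for antiproliferative activity, read by MTT assay, with a stated time of 48 h (a higher number here means a weaker inhibitor, a lower number a stronger inhibitor), compound 1 `CC(CCO)n1cnc2c(Cl)nc(F)nc21` gives 19800 nM, compound 2 `CCCCC(CCO)n1cnc2c(Cl)nc(Cl)nc21` gives 15500 nM and compound 3 `CCCCCCC(CCO)n1cnc2c(Cl)nc(F)nc21` gives 9960 nM. The three values lie within the scatter of one another, so compound 3 does not separate from either neighbour.

Compound 4 `CCCCCCC(CCO)n1cnc2c(Cl)nc(Cl)nc21` carries chloro in place of fluoro on an aromatic carbon, between two ring nitrogen atoms: chloro in place of fluoro on an aromatic carbon. Within the data shown here, no measured step isolates this exchange. Among the measured compounds shown here, the only measured step, a 2.0-fold lower number from compound 1 to compound 3 (0.30 log units; within the scatter), is a change of pentyl in place of hydrogen on the chain and stays within the scatter. Compound 2 already has chloro at this place but also differs from compound 3 in the chain, and the value of compound 3 stays within the scatter of that of compound 2, 15500 nM.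

Nothing here points to a change beyond the scatter in this assay. The expected step is a 1.1-fold lower number from compound 3 to compound 4 (0.04 log units; within the scatter). For compound 4 the estimated value is 9000 nM, with an expected range of 4500 nM to 18000 nM.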

Compound 4, half-maximal inhibitory concentration: 12100 nM
Compound 4: the middle estimate sits 1.3-fold (0.13 log units) below what was measured; low and high end bracket the measured number.
By their numbers in this assay, from the lowest: compounds 3, 4, 2 and 1 (each within the scatter of the next).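

With the chain held fixed, chloro in place of fluoro on the aromatic carbon between two ring nitrogen atoms gives, in this assay, a step within the scatter (a 1.2-fold higher number from compound 3 to compound 4 (0.08 log units; within the scatter)), so this exchange is now read directly and the two halogens do not separate at this position on this chain. With chloro held at that position, ethyl in place of hydrogen on a saturated chain carbon, five bonds along the chain from an aromatic nitrogen, also stays within the scatter (a 1.3-fold lower number from compound 2 to compound 4 (0.11 log units; within the scatter)). No evidence on the origin of these small steps is available.

As far as these compounds go, whether an amine or a methoxy group at this position would move the number beyond the scatter remains open. Also open, from the compounds shown here alone, is whether a longer chain than that of compound 4 would do so.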